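Swapping a naphthalene for a trifluoromethylphenyl on the triazole nitrogen

The source may hold more compounds than are shown below. What is called first, only, known or untested is meant among the compounds shown, and "the series" means these compounds.

Of the compounds shown here, three sharing one core have been measured in a functional assay on MDA-MB-231 cells (Homo sapiens) for antiproliferative activity, with a stated time of 5 days; a higher number here means a weaker inhibitor, a lower number a stronger inhibitor. Compound 1 `O=C1C=CC2(C=C1)OCC(=O)N2c1nc(-c2ccc3ccccc3c2)nn1-c1ccc2ccccc2c1` gives 50 nM in this assay, which places it second highest of the three numbers, with compound 2 `CC1OC2(C=CC(=O)C=C2)N(c2nc(-c3ccc4ccccc4c3)nn2-c2ccc3ccccc3c2)C1=O` at 60 nM and compound 3 `Cc1ccc(-n2nc(-c3cccc4ccccc34)nc2N2C(=O)COC23C=CC(=O)C=C3)cc1` at 40 nM; both neighbours lie within the scatter of compound 1, so the three cannot be ordered.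

Compound 4 `O=C1C=CC2(C=C1)OCC(=O)N2c1nc(-c2ccc3ccccc3c2)nn1-c1ccc(C(F)(F)F)cc1` is compound 1 changed in one place: 4-(trifluoromethyl)phenyl in place of naphthalen-2-yl on an aromatic nitrogen. Among the measured compounds shown here, the only measured single step, a 1.2-fold higher number from compound 1 to compound 2 (0.08 log units; within the scatter), concerns a methyl in place of hydrogen on a saturated ring carbon and says nothing about the aromatic nitrogen. For the measured compounds named here, compound 3 carries a smaller aryl group on that nitrogen, yet it also differs from compound 1 elsewhere, so its value shows only that such a group is compatible with a similar number.

With no direct guidance, the change to compound 4 is expected to produce a step of a 1.4-fold higher number from compound 1 to compound 4 (0.15 log units; within the scatter), essentially none beyond the scatter. Compound 4 is estimated at 70 nM, with a range from 25 nM to 200 nM.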

Compound 4, half-maximal inhibitory concentration: 70 nM
For compound 4 middle estimate and measured number coincide at the digits printed, and the stated range covers the measured number.
By their numbers in this assay, from the lowest: compounds 3, 1, 2 and 4 (each within the scatter of the next).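

On the aromatic nitrogen, the two rings of naphthalen-2-yl give way to the single ring of 4-(trifluoromethyl)phenyl, with the heavy-atom count unchanged, and this assay records a 1.4-fold higher number from compound 1 to compound 4 (0.15 log units; within the scatter) for this swap. Among the compounds shown here, this is the first direct reading at this position: compound 3 differs from compound 1 in more than one place, whereas compound 4 differs from it in this place alone, so one fused ring can be lost here without a step beyond the scatter. No measurement at hand speaks to the reason for this outcome.

A single aryl swap leaves open what an amine, a carboxylic acid or a longer chain on this nitrogen would give. Also open, going by these compounds, are the number for plain phenyl at this place and the result of this swap with the methyl of compound 2 present.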